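The source may hold more compounds than are shown below. What is called first, only, known or untested is meant among the compounds shown, and "the series" means these compounds.

Compound 1 `Cc1ccccc1C#Cc1ccc2c(n1)CCN(C)C2=O` gives > 32000 nM in an assay on HEK293 cells for displacement of a labelled ligand from metabotropic glutamate receptor 5 (Homo sapiens), with a stated time of 2 h (on this read-out lower numbers stand for stronger inhibition and higher numbers for weaker inhibition), which is a limit of the assay and not a number.
Compound 2 `CN1CCc2nc(C#Cc3cccnc3)ccc2C1=O` gives 27400 nM in this assay.
Compound 3 `Cc1ccccc1C#Cc1ccc2c(n1)CCN(C(C)C)C2=O` gives > 32000 nM in this assay, again a limit of the assay and not a number.

Compound 3 thus stands at the limit of > 32000 nM in this assay, at which 2 of the 3 values shown sit; on the numbers shown nothing places it anywhere but at that ceiling. Compound 4 `CC(C)N1CCc2nc(C#Cc3cccs3)ccc2C1=O` differs from compound 3 in one place: thiophen-2-yl in place of 2-methylphenyl on a triple-bonded carbon. Among the measured compounds shown here, only one measured step touches the same position: an at least 1.1-fold lower number from compound 1 to compound 2 (0.06 log units; that floor lies within the scatter), an exchange of the aryl group on the triple-bonded carbon that moved the read-out from a limit to a number close to it. The other measured step, a step that the two limits leave unreadable from compound 1 to compound 3, concerns the substituent on the ring nitrogen and says nothing readable about an aryl exchange. The step into compound 4 therefore carries no expectation beyond the scatter in this assay: the thiophen-2-yl group in place of 2-methylphenyl is expected to leave the value near the ceiling, perhaps just inside it, which is the estimated step of an at least 1.4-fold lower number from compound 3 to compound 4 (0.16 log units; that floor lies within the scatter). Compound 4 is expected at 22000 nM, within 6000 nM to 60000 nM.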

Compound 4, inhibition constant: 1930 nM
Compound 4: the middle estimate sits 11-fold (1.06 log units) above what was measured, outside the stated range (below it).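

In this assay, the group on the triple-bonded carbon proves able to move the read-out well clear of the ceiling: thiophen-2-yl in place of 2-methylphenyl gives an at least 16-fold lower number from compound 3 to compound 4 (1.21 log units; beyond the scatter). Among the compounds shown here, the only earlier exchange at this position, pyridin-3-yl in place of 2-methylphenyl with methyl on the ring nitrogen, gave an at least 1.1-fold lower number from compound 1 to compound 2 (0.06 log units; that floor lies within the scatter), so the earlier compounds showed no readable sensitivity here, and the new step shows that this position can carry a large change even with isopropyl on the ring nitrogen. The true size of the new step remains a floor, as the starting point, compound 3, is a limit of the assay and not a number: the limit of > 32000 nM in this assay, at which 2 of the 4 values shown sit.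

Going by these compounds, the step from methyl to isopropyl on the ring nitrogen cannot be read, so what that substituent contributes stays open, and the two aryl exchanges, made on different nitrogen substituents, cannot be ranked against each other. Also open, on these data alone, is whether the gain belongs to thiophen-2-yl alone or extends to other five-membered rings on the triple-bonded carbon, such as thiophen-3-yl, furan-2-yl or thiazol-2-yl.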